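Swapping Bromo for Trifluoromethyl on a Weak Series

A few compounds are considered here, and "the series" means these few. Any claim that something is new, unique, unknown or untested is made for them only; others in the source may bear on it.

Compound 1 `Fc1ccc(-c2csc(N3N=C(c4ccc(N5CCCCC5)cc4)CC3c3ccc(Cl)cc3)n2)cc1`: in a functional assay on MCF7 cells (Homo sapiens) for antiproliferative activity, read by MTT assay, with a stated time of 72 h (on this read-out lower numbers stand for stronger inhibition and higher numbers for weaker inhibition), compound 1 gives 23100 nM.
Compound 2 `Clc1ccc(-c2csc(N3N=C(c4ccc(N5CCCCC5)cc4)CC3c3ccc(Cl)cc3)n2)cc1`: in this assay compound 2 gives > 100000 nM, which is a limit of the assay and not a number.
Compound 3 `Clc1ccc(C2CC(c3ccc(N4CCCCC4)cc3)=NN2c2nc(-c3ccc(Br)cc3)cs2)cc1`: in this assay compound 3 gives > 100000 nM, again a limit.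

Compound 3 therefore stands at the edge of what this assay can report, sharing that position with compound 2 (the limit of > 100000 nM in this assay, at which 2 of the 3 values shown sit). Only compound 1 yields a real number, and both halogen swaps away from it are weakening: an at least 4.3-fold higher number from compound 1 to compound 2 (0.63 log units; beyond the scatter) and an at least 4.3-fold higher number from compound 1 to compound 3 (0.63 log units; beyond the scatter). Between the two limits the step that the two limits leave unreadable from compound 2 to compound 3.

Compound 4 `FC(F)(F)c1ccc(-c2csc(N3N=C(c4ccc(N5CCCCC5)cc4)CC3c3ccc(Cl)cc3)n2)cc1` carries the change (trifluoromethyl in place of bromo on an aromatic carbon). Among the measured compounds shown here, no trifluoromethyl analogue has been measured, so the expectation rests on the pattern that the larger chloro and bromo groups both fall to the limit while only fluoro gives a number. Compound 4 is expected to show a number no higher from compound 3 to compound 4 (the limit leaves the size open), most likely remaining at the limit. The estimate for compound 4 in this assay is 100000 nM, within 20000 nM to 300000 nM.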

Compound 4, half-maximal inhibitory concentration: 23700 nM
Beside the measured number, compound 4's estimate is 4.2-fold (0.63 log units) above it; measured number inside the range.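

Replacing bromo with trifluoromethyl on this aromatic carbon brings this assay back to a real number, with an at least 4.2-fold lower number from compound 3 to compound 4 (0.62 log units; beyond the scatter), and replacing chloro does the same, with an at least 4.2-fold lower number from compound 2 to compound 4 (0.62 log units; beyond the scatter). The earlier pattern, in which only fluoro gave a number, therefore does not hold, since trifluoromethyl, with 4 heavy atoms against 1 for bromo, gives one too. Trifluoromethyl and fluoro cannot be told apart here, with a 1.0-fold higher number from compound 1 to compound 4 (0.01 log units; within the scatter), so all the readable values in this small set remain weak ones.

On these data alone, the true values of compound 2 and compound 3 stay unknown, since each is only a limit: the limit of > 100000 nM in this assay, at which 2 of the 4 values shown sit. As far as these compounds go, it also remains open whether a nitrile, an amine or a carboxylic acid on this carbon would give a clearly lower number than compound 1 and compound 4.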